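This account rests on a few compounds, and the source may have more. Where it says the series, first, only, none or still open, it means among the compounds named here.

Measured compounds:
compound 1, `COc1cc(-c2cc(/C=C/C(=O)c3ccc(N)cc3)[nH]n2)cc(OC)c1OC`, in a functional assay on RXF 393 cells (Homo sapiens) for inhibition, read by sulforhodamine B assay, with a stated time of 48 h (on this read-out higher numbers stand for weaker inhibition of growth and lower numbers for stronger inhibition of growth), compound 1 gives 3240 nM
compound 2, `COc1cc(-c2cc(/C=C/C(=O)c3ccc(Cl)c(Cl)c3)[nH]n2)cc(OC)c1OC`, in this assay compound 2 gives 12800 nM
compound 3, `COc1ccc(C(=O)/C=C/c2cc(-c3cc(OC)c(OC)c(OC)c3)n[nH]2)cc1`, in this assay compound 3 gives 2560 nM

All three share the same core and differ only in the aromatic group attached to the carbonyl carbon. Compound 3 has the lowest number of the three, but its gap to compound 1 is within the scatter, so the two cannot be told apart; only compound 2 stands clearly apart, as a 5.0-fold lower number from compound 2 to compound 3 (0.70 log units; beyond the scatter) shows.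

Compound 4, `COc1cc(-c2cc(/C=C/C(=O)c3ccc(F)c(F)c3)[nH]n2)cc(OC)c1OC`, is not yet measured. Compared with compound 3 the change is 3,4-difluorophenyl in place of 4-methoxyphenyl on a carbonyl carbon. For the measured compounds named here, two measured steps bear on it, both involving a dihalogenated ring on the same carbonyl carbon: a 4.0-fold higher number from compound 1 to compound 2 (0.60 log units; beyond the scatter) and a 5.0-fold lower number from compound 2 to compound 3 (0.70 log units; beyond the scatter). In both, the compound carrying the 3,4-dichlorophenyl group gave the higher number. Going by the values given here, a 3,4-difluorophenyl group is not identical to a 3,4-dichlorophenyl group, and no fluorinated compound has been measured here, so the comparison is indirect. Still, the expectation is a modestly higher number in this assay for compound 4 than for compound 3, on the order of a 2.3-fold higher number from compound 3 to compound 4 (0.37 log units; beyond the scatter). The estimate for compound 4 is therefore 6000 nM, with a range from 2500 nM to 15000 nM.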

Compound 4, concentration for total growth inhibition: 6340 nM
Compound 4: middle estimate off by 1.1-fold (0.02 log units), on the low side; measured number inside the range.
By their numbers in this assay, from the lowest: compounds 3, 1 and 4 (each within the scatter of the next, the first and the last beyond it); then compound 2.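

For the compounds shown here, compound 4 allows the first direct comparison of two halogenated rings on this carbonyl carbon: in this assay 3,4-difluorophenyl in place of 3,4-dichlorophenyl gives a 2.0-fold lower number from compound 2 to compound 4 (0.31 log units; beyond the scatter) and so the kind of halogen matters here, not only the presence of a dihalogenated ring. The 3,4-difluorophenyl group still stands clearly apart from 4-methoxyphenyl, with a 2.5-fold higher number from compound 3 to compound 4 (0.39 log units; beyond the scatter) at this position, yet a 2.0-fold higher number from compound 1 to compound 4 (0.29 log units; within the scatter) lies within the scatter, so compound 4 cannot be told apart from compound 1, which carries the 4-aminophenyl group. Nothing in the available information explains why these groups rank as they do.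

The compounds shown leave open where other groups on this carbonyl carbon would fall, such as an unsubstituted phenyl ring, a phenyl ring carrying a single fluorine, or one carrying a trifluoromethyl group. They also leave open whether the gap seen here between the fluorinated and chlorinated rings would persist on a different core or in other cell lines.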